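This account rests on a few compounds, and the source may have more. Where it says the series, first, only, none or still open, it means among the compounds named here.

Compound 3 `CCOC(=O)c1c(C)nc(-c2cccc(C#N)c2)n1OCc1ccccc1` gives the lowest of the two numbers reported in a functional assay on a cell-free system (plasma, Oryctolagus cuniculus) for inhibition, with stated times of 5 min, 1 min and 6 min (on this read-out higher numbers stand for weaker inhibition and lower numbers for stronger inhibition), at 5930 nM. Compound 1 `CCOC(=O)c1c(C)nc(-c2cccc(C#N)c2)n1O` gives 17600 nM in this assay, and the step of a 3.0-fold lower number from compound 1 to compound 3 (0.47 log units; beyond the scatter) lies beyond the scatter. Compound 2 `CCOC(=O)c1[nH]c(-c2cccc(C#N)c2)nc1C` reaches only the limit of this assay, > 30000 nM, which is a limit rather than a number (the limit of > 30000 nM in this assay, at which 1 of the 3 values shown sits). Compound 4 `CCOC(=O)c1c(C)nc(-c2cccc(C#N)c2)n1OCc1ccc(C(=O)OC)cc1` differs from compound 3 in one place: methoxycarbonyl in place of hydrogen on an aromatic carbon. The measured steps of a 3.0-fold lower number from compound 1 to compound 3 (0.47 log units; beyond the scatter) and an at least 5.0-fold lower number from compound 2 to compound 3 (0.70 log units; beyond the scatter) concern the benzyl group itself, not a group on its ring, so none of them bears directly on this change. A step of about a 1.3-fold lower number from compound 3 to compound 4 (0.12 log units; within the scatter) is therefore expected, within the scatter. Compound 4 is estimated at 4500 nM, with a range from 1500 nM to 15000 nM.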

Compound 4, half-maximal inhibitory concentration: 9470 nM
For compound 4 the middle estimate is 2.1-fold (0.32 log units) below the measured one, and the stated range covers the measured number.
By their numbers in this assay, from the lowest: compounds 3, 4 and 1 (each within the scatter of the next, the first and the last beyond it). At a limit, above all of these: compound 2.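

In this assay, among the compounds shown here, the step of a 1.6-fold higher number from compound 3 to compound 4 (0.20 log units; within the scatter) is the first test of a group on the benzyl ring itself. For the compounds shown here, at this place on the ring, para to a large group, methoxycarbonyl and hydrogen cannot be told apart, whereas the earlier compounds spoke only to the benzyl group as a whole. No measurement shown gives a reason for this result. On these data alone, whether an amine or a carboxylic acid at this place would also leave the number within the scatter stays open, as does the effect of methoxycarbonyl elsewhere on the ring.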